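Compound 3 to compound 4: a step at the limit

The source may report more compounds than this note shows. Statements on the series, on what has been measured and on what is new or still open speak of the compounds shown alone.

Measured so far in an ADME assay on Huh7.5.1 cells (Homo sapiens) for cytotoxicity, read by WST assay, with a stated time of 48 h; a lower number here means that less compound is tolerated, a higher number that more compound is tolerated (each value is a limit):
compound 1 `Cc1c(-c2ccc(Cc3ccc([S+]([O-])C(F)(F)F)cc3)cc2)[nH]c2cccc(F)c2c1=O` gives > 5000 nM
compound 2 `Cc1c(-c2ccc(Cc3ccc(OC(F)F)cc3)cc2)[nH]c2cccc(F)c2c1=O` gives > 5000 nM
compound 3 `Cc1c(-c2ccc(Cc3ccc(S(F)(F)(F)(F)F)cc3)cc2)[nH]c2cccc(F)c2c1=O` gives > 5000 nM
Not yet measured: compound 4 `COc1ccc(Cc2ccc(-c3[nH]c4cccc(F)c4c(=O)c3C)cc2)cc1`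

Compound 3 gives > 5000 nM as a limit and not a number. It has no readable rank in the series, where the evidence is the limit of > 5000 nM in this assay, at which 3 of the 3 values shown sit, and no more.

The change to compound 4 is a group of 2 heavy atoms (1 carbon, 1 oxygen; no ring) in place of a group of 6 heavy atoms (5 fluorine, 1 sulfur; no ring), on an aromatic carbon, with methoxy entering para to a large group on a six-membered aromatic ring of carbon only.

Among the compounds with values here, three measured steps concern the same place: a step that the two limits leave unreadable from compound 1 to compound 2, a step that the two limits leave unreadable from compound 1 to compound 3 and a step that the two limits leave unreadable from compound 2 to compound 3. None has a readable size, so none shows how far a change here moves the read-out. Compound 1, compound 2 and compound 3 carry different groups at this place, and all three remain at a limit. Within the data shown here, no measured compound carries methoxy.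

No step beyond the scatter is expected in this assay, and no direction can be stated. The expected step is a step that the limit leaves unreadable from compound 3 to compound 4 and rests on compound 3 at > 5000 nM as a limit. Compound 4 will most likely also report only a limit. The estimate for compound 4 is 7000 nM with an expected range from 3000 nM to 20000 nM in this read-out.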

Compound 4, half-maximal cytotoxic concentration: > 10000 nM
Compound 4 gave a limit, no number; the forecaster's own chance of this, stated with the estimate: 80%; at least 1.4-fold (0.15 log units) between middle value and limit.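

In this assay compound 4 gives > 10000 nM, which is a limit and not a number. The steps to compound 4 from compound 1, compound 2 and compound 3 cannot be read, as all four values are limits. The compounds shown leave open at what concentration any of them reaches the half-maximal cytotoxic effect, and whether methoxy differs from the other groups at this place.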